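Swapping Chloro for Pyrrolidinyl on a Cyanoacrylic Acid

The source may report more compounds than this note shows. Statements on the series, on what has been measured and on what is new or still open speak of the compounds shown alone.

Compound 1 `N#C/C(=C\c1ccc(Cl)cc1)C(=O)O` was tested in an assay on RBE4 cells for inhibition of Monocarboxylate transporter 1 (Rattus norvegicus), with a stated time of 15 min (a higher number here means a weaker inhibitor, a lower number a stronger inhibitor), and gives 500 nM. Going by the values given here, of the two compounds measured so far, compound 1 stands at the highest number; its nearest neighbour, compound 2 `CCCCN(CCCC)c1ccc(/C=C(\C#N)C(=O)O)cc1`, gives 30 nM, a gap well beyond the usual scatter. Compound 3 `N#C/C(=C\c1ccc(N2CCCC2)cc1)C(=O)O` has not yet been measured and differs from compound 1 in a single place: pyrrolidin-1-yl in place of chloro on an aromatic carbon. Among the compounds with values here, no step between measured compounds that differ in one place is available, so the likely size of this change must be judged from compound 1 and compound 2 alone. Because compound 2 gives 30 nM and also carries a nitrogen attached to the aromatic ring, the step from compound 1 to compound 3 is expected to be a 6.3-fold lower number from compound 1 to compound 3 (0.80 log units; beyond the scatter), a clear drop in the number. Compound 3 is therefore estimated at 80 nM, within a range from 25 nM to 250 nM.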

Compound 3, half-maximal inhibitory concentration: 70 nM
The estimate for compound 3 lay 1.1-fold (0.06 log units) above the measured number; low and high end bracket the measured number.
By their numbers in this assay, from the lowest: compound 2; then compound 3; then compound 1.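

Going by these compounds alone, the step gives the first direct reading at this aromatic carbon: in this assay, pyrrolidin-1-yl in place of chloro brings a 7.1-fold lower number from compound 1 to compound 3 (0.85 log units; beyond the scatter), a change beyond the usual scatter. The position therefore takes a group of 5 heavy atoms carrying a five-membered non-aromatic ring, and the number falls rather than rises when that group enters. Nothing at hand accounts for this fall.

From the compounds shown here alone, whether the ring matters, or whether the nitrogen on the aromatic carbon is enough, stays open; a plain amine, dimethylamino or piperidin-1-yl at this carbon would help to separate the two. The compounds shown also leave open whether cyclopentyl, a ring of carbon only, would give a similar number.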